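Benzylthio substitution on the shared core of compound 1

The source may report more compounds than this note shows. Statements on the series, on what has been measured and on what is new or still open speak of the compounds shown alone.

Compound 1 `Sc1nnc(-c2ccc3c(c2)OCCO3)n1-c1ccccc1` gives 47000 nM in a functional assay on BGC-823 cells (Homo sapiens) for antiproliferative activity, read by MTT assay, with a stated time of 24 h (a lower number here means a stronger inhibitor, a higher number a weaker inhibitor), the lower of the two plain numbers here, with compound 2 `Clc1cccc(CSc2nnc(-c3ccc4c(c3)OCCO4)n2-c2ccccc2)c1` at 51200 nM sitting close by. Compound 3 `Fc1ccc(CSc2nnc(-c3ccc4c(c3)OCCO4)n2-c2ccccc2)cc1` reports only a limit, > 100000 nM. The steps of a 1.1-fold higher number from compound 1 to compound 2 (0.04 log units; within the scatter) and an at least 2.1-fold higher number from compound 1 to compound 3 (0.32 log units; beyond the scatter) both place a benzyl group on the sulfur of compound 1; the pair is separated by an at least 1.9-fold higher number from compound 2 to compound 3 (0.29 log units; that floor lies within the scatter). Compound 4 `Brc1ccccc1CSc1nnc(-c2ccc3c(c2)OCCO3)n1-c1ccccc1` carries the change (2-bromobenzyl in place of hydrogen on a sulfur). One measured benzyl step is flat and the other loses at least modestly, so in this assay compound 4 is expected to land between those outcomes, a 1.5-fold higher number from compound 1 to compound 4 (0.17 log units; within the scatter), with the limit of > 100000 nM in this assay, at which 1 of the 3 values shown sits, a reminder that a limit rather than a number may be returned. The estimate for compound 4 is 70000 nM, ranging from 35000 nM to 150000 nM.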

Compound 4, half-maximal inhibitory concentration: > 100000 nM
Compound 4: a limit, no number; the forecaster's own chance of this, stated with the estimate: 35%; at least 1.4-fold (0.15 log units) between middle value and limit.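

In this assay, 2-bromobenzyl on the sulfur gives an at least 2.1-fold higher number from compound 1 to compound 4 (0.32 log units; beyond the scatter), so two of the three benzyl groups now show a loss beyond the scatter, and compound 2 goes against that pattern. Set against 3-chlorobenzyl, the 2-bromobenzyl group gives an at least 1.9-fold higher number from compound 2 to compound 4 (0.29 log units; that floor lies within the scatter). The step from compound 3 to compound 4 cannot be read, both values being limits, and the series now holds a further limit: the limit of > 100000 nM in this assay, at which 2 of the 4 values shown sit.

Halogen and ring position change together across compound 2, compound 3 and compound 4, and these compounds do not separate the two. On these data alone, whether an amine on the benzyl ring or a longer chain on the sulfur returns a plain number in this assay stays open.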